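Shifting a Trifluoromethyl Group on a Benzamide Inhibitor

The source may hold more compounds than are shown below. What is called first, only, known or untested is meant among the compounds shown, and "the series" means these compounds.

Measured compounds:
compound 1 `Cc1ccc(NC(=O)c2ccc(CN3CCCN(C)CC3)cc2)cc1-n1cc(-c2cnc3ccnn3c2)cn1` — 6830 nM
compound 2 `Cc1ccc(NC(=O)c2cccc(C(F)(F)F)c2)cc1-n1cc(-c2cnc3cccnn23)cn1` — 13700 nM

In a functional assay on U-937 cells (Homo sapiens) for antiproliferative activity, read by CCK-8 assay, with a stated time of 24 h (a higher number here means a weaker inhibitor, a lower number a stronger inhibitor), compound 2 gives 13700 nM. Compound 1 gives 6830 nM in this assay. These two values lie within the scatter of each other, so neither compound can be called the stronger inhibitor. Compound 3 `Cc1ccc(NC(=O)c2ccc(C(F)(F)F)cc2)cc1-n1cc(-c2cnc3cccnn23)cn1` differs from compound 2 in one place: 4-(trifluoromethyl)phenyl in place of 3-(trifluoromethyl)phenyl on a carbonyl carbon. Within the data shown here, no comparable step between measured compounds is known here, so the expected change is none beyond the scatter. Compound 3 is therefore expected to give about 11000 nM, within a range from 3500 nM to 35000 nM. The step expected is a 1.2-fold lower number from compound 2 to compound 3 (0.10 log units; within the scatter).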

Compound 3, half-maximal inhibitory concentration: > 20000 nM
Compound 3: a limit, no number (the forecaster's own chance of this, stated with the estimate: 15%); middle value at least 1.8-fold (0.25 log units) from the limit.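

In this assay, moving the trifluoromethyl group, with the same atoms throughout, gives an at least 1.4-fold higher number from compound 2 to compound 3 (0.16 log units; that floor lies within the scatter). Among these compounds, this is the first step that can be read at this place on the carbonyl carbon, and it gives no sign of a stronger inhibitor, though its floor does not establish a real loss either. For compound 3 the reading is a limit, not a number: the limit of > 20000 nM in this assay, at which 1 of the 3 values shown sits.

On these data alone, how far compound 3 truly lies from compound 2 stays open. So does whether a carboxylic acid or a nitrile in place of the trifluoromethyl group would change the number.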